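A Ring Swap on the Amide of Compound 1

A few compounds are considered here, and "the series" means these few. Any claim that something is new, unique, unknown or untested is made for them only; others in the source may bear on it.

Compound 1 `COC1CN(C(=O)/C=C/c2ccncc2-c2ccc3ccccc3c2)C1` carries an amide built on a 3-methoxyazetidin-1-yl group. In a functional assay on HCT-116 cells (Homo sapiens) for inhibition, read by MTT assay, with a stated time of 72 h (on this read-out lower numbers stand for stronger inhibition of growth and higher numbers for weaker inhibition of growth), compound 1 gives only a limit, > 30000 nM, so no single number stands for it. Two related compounds appear beside it without results: compound 2 `NC(=O)/C=C/c1ccncc1Br`, for which this assay reports "not determined" (no result reported), and compound 3 `O=C(/C=C/c1ccncc1-c1ccc2cccnc2c1)N1CCOCC1`, for which this assay reports "not determined" (no result reported). Compound 1 therefore stands alone among the measured compounds, and it sits at the limit of > 30000 nM in this assay, at which 1 of the 3 values shown sits.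

Compound 4 `O=C(/C=C/c1ccncc1-c1ccc2ccccc2c1)N1CCOCC1` differs from compound 1 in one place: morpholin-4-yl in place of 3-methoxyazetidin-1-yl on a carbonyl carbon. Going by the values given here, no step between two measured compounds is available, so the size of this change cannot be read from the data. With compound 1 giving only a limit, the step of a number no higher from compound 1 to compound 4 (the limit leaves the size open) is expected to be none beyond the scatter, and a limit rather than a number is the likely outcome. Compound 4 is estimated at 30000 nM, within a range from 10000 nM to 100000 nM.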

Compound 4, concentration for 50% growth inhibition: 6040 nM
Compound 4: middle estimate off by 5.0-fold (0.70 log units), on the high side; measured number outside the range, below it.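

Exchanging one ring for the other on the carbonyl carbon yields a real number: in this assay compound 4 gives 6040 nM. Morpholin-4-yl in place of 3-methoxyazetidin-1-yl gives an at least 4.9-fold lower number from compound 1 to compound 4 (0.69 log units; beyond the scatter), so growth inhibition at this position depends on which ring the amide carries, even though both groups have the same count of heavy atoms. The true size of the step stays unknown, since compound 1 has only a limit and not a number: the limit of > 30000 nM in this assay, at which 1 of the 4 values shown sits.

On these data alone, whether a piperidin-1-yl ring, which lacks the ring oxygen, or an open-chain dimethylamino group on the same carbonyl carbon would keep this growth inhibition remains open. Going by these compounds alone, no result stands for compound 2 or compound 3, so no step to either of them can be read.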